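Fluoro for ethyl on the second core of the series

The source may report more compounds than this note shows. Statements on the series, on what has been measured and on what is new or still open speak of the compounds shown alone.

Measured so far:
compound 1, `CCc1ccc2nc(C(=O)Nc3c(F)cc(-c4cccc(F)c4)cc3F)c(C)c(O)c2c1`: 31.2%
compound 2, `Cc1c(C(=O)Nc2c(F)cc(-c3cccc(F)c3)cc2F)nc2ccc(F)cc2c1O`: 22.3%
compound 3, `CCc1ccc2nc(C(=O)Nc3c(F)cc(-c4cccc(F)c4)cc3F)c(C)c(C(=O)O)c2c1`: 15.2%

Compound 4, `Cc1c(C(=O)Nc2c(F)cc(-c3cccc(F)c3)cc2F)nc2ccc(F)cc2c1C(=O)O`, is not yet measured in a functional assay on Hep 3B2 cells (Homo sapiens) for antiproliferative activity, read by MTT assay, with a stated time of 24 h, tested at 3.7 ug/mL; a higher number here means a stronger effect of the compound at the concentration tested, a lower number a weaker effect.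

The change from compound 3 to compound 4 is fluoro in place of ethyl on an aromatic carbon. The same change is already measured once, from compound 1 to compound 2, as fluoro in place of ethyl on an aromatic carbon, where it gave a number 8.9 percentage points lower from compound 1 to compound 2 (within the scatter). The place of the change reads the same in both cases, so the change is the same one.

The core on which it is now repeated differs from the core of compound 1 by carboxy in place of hydroxy on an aromatic carbon, and that core change gave a number 16 percentage points lower from compound 1 to compound 3 (beyond the scatter). Whether the step seen from compound 1 to compound 2 carries over to this second core is not known from anything measured.

For compound 4 in this assay a step of a number 6.2 percentage points lower from compound 3 to compound 4 (within the scatter) is expected, resting on the single earlier occurrence, a number 8.9 percentage points lower from compound 1 to compound 2 (within the scatter), with compound 3 at 15.2% as the starting point. The estimate for compound 4 is 9%, expected between 0% and 21%.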

Compound 4, a percentage reported as inhibition, at one concentration (the size of the read-out at that concentration, not a potency): 11.2%
Compound 4: middle estimate off by 2.2 percentage points, on the low side, within the range that was stated.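

In this assay, the repeat of fluoro in place of ethyl gives a number 4 percentage points lower from compound 3 to compound 4 (within the scatter), which agrees with the earlier step: the same change on two cores in this assay, a number 8.9 percentage points lower (within the scatter) from compound 1 to compound 2 and a number 4 percentage points lower (within the scatter) from compound 3 to compound 4, 4.9 percentage points apart, within the scatter of two such steps. Carboxy in place of hydroxy, read on the fluoro-bearing compounds, gives a number 11.1 percentage points lower from compound 2 to compound 4 (beyond the scatter), and this also agrees with its counterpart: the same change on two cores in this assay, a number 16 percentage points lower (beyond the scatter) from compound 1 to compound 3 and a number 11.1 percentage points lower (beyond the scatter) from compound 2 to compound 4, 4.9 percentage points apart, within the scatter of two such steps. Across these four compounds, neither change shows a detectable dependence on the core that carries it, but both fluoro for ethyl steps lie within the scatter, so they show no clear effect of that change on either core, and two cores cannot establish that either change will transfer to a further core.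

The compounds shown leave open how other groups would read on the aromatic carbon that carries ethyl or fluoro, such as chloro, methoxy or a longer chain. They also leave open whether a group other than hydroxy or carboxy at the second site, such as an amine or a methyl ester, would follow the same course.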